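A few compounds are considered here, and "the series" means these few. Any claim that something is new, unique, unknown or untested is made for them only; others in the source may bear on it.

Among the measured compounds shown here, compound 1 `NCC(=O)NCc1nncn1-c1ccc(Cl)cc1C(=O)c1ccccc1` is the smaller of the two numbers so far in a functional assay on the whole organism for antagonist activity, with Mus musculus as the target (a higher number here means that more compound is needed for the effect, a lower number that less compound is needed), where compound 1 gives 5.71 mg/kg. Compound 2 `CN(C(=O)CNC(=O)CN)c1ccc(Cl)cc1C(=O)c1ccccc1` in this assay gives 10.9 mg/kg, which sits within the scatter of compound 1, so no order between the two is claimed. Compound 3 `Cc1nnc(CNC(=O)CN)n1-c1ccc(Cl)cc1C(=O)c1ccccc1` is not yet measured; it differs from compound 1 by methyl in place of hydrogen on an aromatic carbon. For the measured compounds named here, no step between measured compounds bears on this change, so compound 3 is expected to stay within the scatter of compound 1, with a 1.0-fold lower number from compound 1 to compound 3 (0.02 log units; within the scatter) as the expected step. The estimate for compound 3 in this assay is 5.5 mg/kg, between 2.5 mg/kg and 12 mg/kg.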

Compound 3, dose for half-maximal effect: 3.02 mg/kg
The estimate for compound 3 lay 1.8-fold (0.26 log units) above the measured number; low and high end bracket the measured number.
By their numbers in this assay, from the lowest: compounds 3, 1 and 2 (each within the scatter of the next, the first and the last beyond it).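

In this assay methyl in place of hydrogen on the aromatic carbon between two ring nitrogen atoms gives a 1.9-fold lower number from compound 1 to compound 3 (0.28 log units; within the scatter) and so this position takes methyl without a step beyond the scatter. Among the compounds shown here, this is the first reading at this carbon, and it comes from a single pair. No measurement at hand bears on the reason for this result. As far as these compounds go, whether an ethyl group, an amine or a carboxylic acid on this carbon also stays within the scatter of compound 1 remains open.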